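A Second Chloro on the Urea Phenyl Ring

A few compounds are considered here, and "the series" means these few. Any claim that something is new, unique, unknown or untested is made for them only; others in the source may bear on it.

Two urea compounds have been measured in a functional assay on NCI-H460 cells (Homo sapiens) for cytotoxicity, read by MTT assay, with a stated time of 72 h; a lower number here means a stronger inhibitor, a higher number a weaker inhibitor. Compound 1 `CCN(CC)CCCNc1nc(-c2ccc(NC(=O)Nc3ccc(F)cc3)cc2)nc2c(Cl)c(Cl)sc12` carries a 4-fluorophenyl on its urea nitrogen, and in this assay compound 1 gives 450 nM. Compound 2 `CCN(CC)CCCNc1nc(-c2ccc(NC(=O)Nc3ccccc3Cl)cc2)nc2c(Cl)c(Cl)sc12` carries a 2-chlorophenyl in that place, and in this assay compound 2 gives 330 nM. The step of a 1.4-fold lower number from compound 1 to compound 2 (0.13 log units; within the scatter) separates them, so compound 2 stands at one end of the two numbers shown, though its gap to compound 1 lies within the scatter.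

Compound 3 `CCN(CC)CCCNc1nc(-c2ccc(NC(=O)Nc3ccc(Cl)cc3Cl)cc2)nc2c(Cl)c(Cl)sc12` differs from compound 2 by chloro in place of hydrogen on an aromatic carbon, on an aromatic carbon of a six-membered aromatic ring of carbon only, meta to a chloro group and para to a large group. Among the compounds with values here, the only measured step that bears on this change is a 1.4-fold lower number from compound 1 to compound 2 (0.13 log units; within the scatter), which exchanged one halogenated phenyl for another and stayed within the scatter; compound 1, whose fluoro sits para to a large group on the same ring, gave 450 nM. The step of a 1.1-fold lower number from compound 2 to compound 3 (0.04 log units; within the scatter) is therefore expected to be small, with no direction beyond the scatter. Compound 3 is estimated at 300 nM, with a range from 130 nM to 700 nM.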

Compound 3, half-maximal inhibitory concentration: 1170 nM
For compound 3 the middle estimate is 3.9-fold (0.59 log units) below the measured one; measured number outside the range, above it.
By their numbers in this assay, from the lowest: compounds 2 and 1 (each within the scatter of the next); then compound 3.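

Placing chloro on the aromatic carbon para to a large group and meta to a chloro group weakens the compound in this assay, with a 3.5-fold higher number from compound 2 to compound 3 (0.55 log units; beyond the scatter), the first change on this phenyl ring to lie beyond the scatter. The 2,4-dichlorophenyl also separates from the 4-fluorophenyl, with a 2.6-fold higher number from compound 1 to compound 3 (0.41 log units; beyond the scatter), which makes compound 3 the weakest of the three, while compound 1 and compound 2 remain within the scatter of each other; a halogen in this place is thus not enough on its own to give the weaker number, as compound 1 carries fluoro there. Nothing available here accounts for the loss of activity with this second chloro.

The compounds shown leave open whether a 4-chlorophenyl, with a single chloro para to the large group, would give a number near that of compound 3, or whether the weaker number needs both chloro groups on the ring. From the compounds shown here alone, it also remains open how a methyl or a methoxy group on this same carbon would compare with the chloro.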